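The source may hold more compounds than are shown below. What is called first, only, known or untested is meant among the compounds shown, and "the series" means these compounds.

Measured in a functional assay on RS4-11 cells (Homo sapiens) for inhibition, read by CCK-8 assay, with a stated time of 48 h; a higher number here means a weaker inhibitor, a lower number a stronger inhibitor:
compound 1 `O=C(NCCNS(=O)(=O)c1ccc(-c2ccccc2Oc2ccc(O)c(O)c2)s1)Nc1cc(Cl)cc(Cl)c1`: 4500 nM
compound 2 `COc1ccc(NC(=O)NCCNS(=O)(=O)c2sccc2-c2ccc(C)cc2Oc2ccc(O)c(O)c2)cc1`: 8200 nM
compound 3 `O=[N+]([O-])c1ccc(NC(=S)NCCNS(=O)(=O)c2ccc(-c3ccccc3OCc3ccccc3)s2)cc1`: 11300 nM

Compound 2, at 8200 nM, holds the middle place of these three numbers, and its gaps to compound 1 and to compound 3 both lie within the usual scatter of repeated measurements. The three compounds differ from one another in more than one place, so the series offers no measured single change to learn from.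

Compound 4 `COc1ccc(NC(=S)NCCNS(=O)(=O)c2sccc2-c2ccc(C)cc2Oc2ccc(O)c(O)c2)cc1` is compound 2 with one change. The (4-methoxyphenyl)carbamoyl group on an amine nitrogen gives way to a group with no common name: a group of 11 heavy atoms (8 carbon, 1 nitrogen, 1 oxygen, 1 sulfur; one six-membered aromatic ring of carbon only) in place of a group of 11 heavy atoms (8 carbon, 1 nitrogen, 2 oxygen; one six-membered aromatic ring of carbon only), on an amine nitrogen. The count of heavy atoms stays the same, with sulfur taking the place of one oxygen.

Compound 3 also contains sulfur in its corresponding group and gives 11300 nM, but it differs from compound 2 elsewhere too, so it offers only weak guidance. In this assay no step beyond the scatter is expected for this exchange, and any direction is uncertain. The expected step is a 1.1-fold higher number from compound 2 to compound 4 (0.04 log units; within the scatter). The estimated value for compound 4 is 9000 nM, with an expected range from 3800 nM to 20000 nM.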

Compound 4, half-maximal inhibitory concentration: 8300 nM
Estimate against measurement, compound 4: 1.1-fold (0.04 log units) above, and the stated range covers the measured number.
By their numbers in this assay, from the lowest: compounds 1, 2, 4 and 3 (each within the scatter of the next, the first and the last beyond it).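

Among these compounds, the exchange of the (4-methoxyphenyl)carbamoyl group on the amine nitrogen for its counterpart with sulfur in place of one oxygen is the first single change this series offers, and in this assay it amounts to a 1.0-fold higher number from compound 2 to compound 4 (0.01 log units; within the scatter). Compound 2 and compound 4 therefore cannot be told apart in this read-out, so on this core and with this methoxy-bearing aromatic ring, the carbonyl oxygen and the sulfur that replaces it are interchangeable as far as this assay can show. Nothing measured here offers an explanation for this result.

On these data alone, it remains open whether the same exchange would be as silent on the core of compound 1 or with a different aromatic ring, since compound 1 and compound 3 differ from compound 2 in more than one place and so cannot answer that question. Also open, as far as these compounds go, is how this amine nitrogen would tolerate a larger departure from the present linking group, such as a guanidine or a plain amide, or a cyclohexyl ring in place of the methoxy-bearing aromatic ring.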